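The source may hold more compounds than are shown below. What is called first, only, known or untested is meant among the compounds shown, and "the series" means these compounds.

Of the compounds shown here, two of a shared core have been measured in an assay on isolated protein for inhibition of Aromatase (Homo sapiens), read by ELISA, using NADPH, with a stated time of 24 h; a lower number here means a stronger inhibitor, a higher number a weaker inhibitor. Compound 1, `Fc1ccc(-c2[nH]c3cc(Cl)ccc3c2Cn2ccnc2)cc1`, gives 32.3 nM. Compound 2, `Fc1ccc(-c2[nH]c3cc(F)ccc3c2Cn2cncn2)cc1`, gives 54.4 nM in this assay, and the number for compound 1 lies within the scatter of it, so the two cannot be told apart. Compound 3, `Fc1ccc(-c2[nH]c3cc(Cl)ccc3c2Cn2cncn2)cc1`, differs from compound 2 in one place: chloro in place of fluoro on an aromatic carbon. Among the measured compounds shown here, no measured pair shows this change alone, so no step beyond the scatter is expected, with at most a slight drift toward a lower number. For compound 3 the estimate is 40 nM, within 15 nM to 110 nM, a step of a 1.4-fold lower number from compound 2 to compound 3 (0.13 log units; within the scatter).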

Compound 3, half-maximal inhibitory concentration: 96.9 nM
Beside the measured number, compound 3's estimate is 2.4-fold (0.38 log units) below it; measured number inside the range.
By their numbers in this assay, from the lowest: compounds 1, 2 and 3 (each within the scatter of the next, the first and the last beyond it).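

Putting chloro in place of fluoro on this aromatic carbon gives a 1.8-fold higher number from compound 2 to compound 3 (0.25 log units; within the scatter) and so leaves the two halogens indistinguishable at this position in this assay. The larger change lies elsewhere in the molecule: with chloro held fixed, 1H-1,2,4-triazol-1-yl in place of 1H-imidazol-1-yl on the saturated chain carbon gives a 3.0-fold higher number from compound 1 to compound 3 (0.48 log units; beyond the scatter) as a modest loss of inhibition. Nothing available explains either result.

From the compounds shown here alone, it remains open how a methoxy group or a nitrile on this aromatic carbon would read. Also open, going by these compounds, is whether the same exchange of rings would give a similar step with fluoro in place of chloro.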